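Swapping an Amide for a Pyridine Amine on a Shared Core

This account rests on a few compounds, and the source may have more. Where it says the series, first, only, none or still open, it means among the compounds named here.

Compound 1 `CC(=O)c1cc(C(=O)N[C@@H](C)Cn2ccc(-c3cc(F)c(C#N)c(Cl)c3)n2)n[nH]1`: 1100 nM
Compound 2 `C[C@@H](Cn1ccc(-c2ccc(C#N)c(Cl)c2)n1)NC(=O)c1ccccc1F`: 1810 nM

Of the compounds shown here, two have been tested in a functional assay on LNCaP cells (Homo sapiens) for antiproliferative activity, read by CCK-8 assay, with a stated time of 6 days; on this read-out higher numbers stand for weaker inhibition and lower numbers for stronger inhibition. In this assay compound 1 gives 1100 nM. In this assay compound 2 gives 1810 nM, the higher of the two numbers, though the two values lie within the scatter of each other and so cannot be ranked. Compound 3 `C[C@@H](Cn1ccc(-c2ccc(C#N)c(Cl)c2)n1)Nc1ccncc1` has not yet been measured. It differs from compound 2 in one place: pyridin-4-yl in place of (2-fluorophenyl)carbonyl on an amine nitrogen. Within the data shown here, no pair of measured compounds shows a change of this kind, so there is no measured step to lean on; the expectation rests on the value of compound 2 alone. The change is expected to shift the number in this assay only modestly, if at all, with an expected step of a 1.4-fold higher number from compound 2 to compound 3 (0.14 log units; within the scatter) leaning toward weaker inhibition. Compound 3 is therefore estimated at 2500 nM, with a range from 600 nM to 10000 nM.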

Compound 3, half-maximal inhibitory concentration: 2560 nM
Compound 3: middle estimate off by 1.0-fold (0.01 log units), on the low side; the range from low to high includes it.
By their numbers in this assay, from the lowest: compounds 1, 2 and 3 (each within the scatter of the next, the first and the last beyond it).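

Moving from an amide to an aryl amine at this position gives, in this assay, a 1.4-fold higher number from compound 2 to compound 3 (0.15 log units; within the scatter), where pyridin-4-yl takes the place of (2-fluorophenyl)carbonyl on the amine nitrogen. Among these compounds, this is the first measured change at this nitrogen, and it shows that the carbonyl and the fluorinated benzene ring can leave together without a change beyond the scatter, provided pyridin-4-yl enters. No measurement here bears on why the two groups give such similar numbers.

Because the carbonyl, the fluorine and the ring type all change in one step, the compounds shown cannot tell what each contributes on its own. A pyridin-4-ylcarbonyl group would keep the carbonyl with the pyridine ring, and a plain phenyl on the amine nitrogen would keep the direct link without the ring nitrogen, so each would separate these features.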